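Removing one hydroxy from the 2,3-dihydroxyphenyl head

The source may hold more compounds than are shown below. What is called first, only, known or untested is meant among the compounds shown, and "the series" means these compounds.

Compound 1 `Oc1cccc(/C=N/c2ccc(OCc3ccccc3)cc2)c1O` gives 13300 nM in a functional assay, with a stated time of 30 min (a lower number here means a stronger inhibitor, a higher number a weaker inhibitor), the lowest of the two numbers in hand. Compound 2 `Oc1ccc(/C=N/c2ccc(OCc3ccccc3)cc2)c(O)c1O` gives 43400 nM, and the step of a 3.3-fold higher number from compound 1 to compound 2 (0.51 log units; beyond the scatter) shows that an added hydroxy weakens inhibition. Compound 3 `COc1ccc(O)c(/C=N/c2ccc(OCc3ccccc3)cc2)c1` reports only (the limit of > 200000 nM in this assay, at which 1 of the 3 values shown sits); its reading > 200000 nM is a limit of this assay, not a number.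

Compound 4 `Oc1ccccc1/C=N/c1ccc(OCc2ccccc2)cc1` differs from compound 1 by hydrogen in place of hydroxy on an aromatic carbon: the 2,3-dihydroxyphenyl head becomes 2-hydroxyphenyl. Within the data shown here, only the step of a 3.3-fold higher number from compound 1 to compound 2 (0.51 log units; beyond the scatter) touches a hydroxy on that ring, and it ran in the opposite sense, while compound 3 sits at the limit. A modest loss is therefore expected for compound 4, a 3.0-fold higher number from compound 1 to compound 4 (0.48 log units; beyond the scatter). Compound 4 is estimated at 40000 nM, between 10000 nM and 200000 nM.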

Compound 4, half-maximal inhibitory concentration: > 200000 nM
Compound 4: a limit, no number; the forecaster's own chance of this, stated with the estimate: 25%; middle value at least 5.0-fold (0.69 log units) from the limit.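

In this assay the change from 2,3-dihydroxyphenyl to 2-hydroxyphenyl gives an at least 15-fold higher number from compound 1 to compound 4 (1.17 log units; beyond the scatter) as its step, so the hydroxy at this position counts for much more than the added hydroxy in a 3.3-fold higher number from compound 1 to compound 2 (0.51 log units; beyond the scatter) as the other step on this ring. Removing this hydroxy and adding a further one both raise the number, which leaves the 2,3-dihydroxyphenyl head of compound 1 the best of the heads shown. The reading for compound 4 is a limit, not a number, and the step from compound 3 to compound 4 cannot be read: the limit of > 200000 nM in this assay, at which 2 of the 4 values shown sit.

From the compounds shown here alone, how far compound 4 lies past that limit stays open. So does whether an amine or a carboxylic acid on this carbon could stand in for the hydroxy.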